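A few compounds are considered here, and "the series" means these few. Any claim that something is new, unique, unknown or untested is made for them only; others in the source may bear on it.

Measured compounds:
- compound 1, `O=C(O)c1ccc(C(=O)/C(=C\c2ccc(Br)c([N+](=O)[O-])c2)SCc2ccc(F)cc2)cc1`, 1000 nM
- compound 2, `O=C(O)c1ccc(C(=O)/C(=C\c2ccc(O)c([N+](=O)[O-])c2)SCc2ccc(F)cc2)cc1`, only a limit, > 100000 nM
- compound 3, `O=C(/C(=C\c1ccc(Br)cc1)SCc1ccc(F)cc1)c1ccc(Br)cc1`, 25000 nM

In a functional assay on DU-145 cells (Homo sapiens) for inhibition, read by trypan blue exclusion, with a stated time of 96 h (a higher number here means a weaker inhibitor of growth, a lower number a stronger inhibitor of growth), compound 1 gives 1000 nM. Compound 2 gives only a limit in this assay, > 100000 nM. Compound 3 gives 25000 nM in this assay, the highest number among the measured compounds. The difference between the core of compound 1 and the core of compound 3 is not broken down here.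

The change from compound 1 to compound 2 is hydroxy in place of bromo on an aromatic carbon and gave an at least 100-fold higher number from compound 1 to compound 2 (2.00 log units; beyond the scatter), running into (the limit of > 100000 nM in this assay, at which 1 of the 3 values shown sits). The change from compound 3 to compound 4, `O=C(/C(=C\c1ccc(O)cc1)SCc1ccc(F)cc1)c1ccc(Br)cc1`, is hydroxy in place of bromo on an aromatic carbon, the same kind of change; around the place it differs in that compound 1 carries the change ortho to a nitro group, compound 3 does not.

Compound 4 is not yet measured in this assay. On the measured step from compound 1 to compound 2, a step of a 6.0-fold higher number from compound 3 to compound 4 (0.78 log units; beyond the scatter) is expected from compound 3 to compound 4, starting already from the high number of compound 3. Compound 4 is thus estimated at 150000 nM, most likely reported only as a limit.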

Compound 4, concentration for 50% growth inhibition: 10000 nM
The estimate for compound 4 lay 15-fold (1.18 log units) above the measured number; measured number below the stated range.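

In this assay, hydroxy in place of bromo on an aromatic carbon gave a 2.5-fold lower number from compound 3 to compound 4 (0.40 log units; beyond the scatter), so the change did not carry over from one core to the other in either direction or size: the same change on two cores in this assay, an at least 100-fold higher number (2.00 log units; beyond the scatter) from compound 1 to compound 2 and a 2.5-fold lower number (0.40 log units; beyond the scatter) from compound 3 to compound 4, at least 250-fold (2.39 log units) apart, beyond the scatter of two such steps

On these data alone, compound 2 is reported only as a limit, > 100000 nM, so the true size of the step on the core of compound 1 remains unknown. The two cores differ in more than one place, including a nitro group and a carboxylic acid found only on the core of compound 1, so these two pairs show that the result of the change varied between the cores but not which difference separates the outcomes.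

Still open, as far as these compounds go, is how the change behaves on a core carrying only the nitro group or only the carboxylic acid. Also open, from the compounds shown here alone, is whether an amine or a methoxy group in place of bromo would follow the direction seen on either core in this assay.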